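Moving the Chlorine Around on the Phenoxy Ring

This account rests on a few compounds, and the source may have more. Where it says the series, first, only, none or still open, it means among the compounds named here.

Measured compounds:
- compound 1, `Clc1cccc(Oc2cncc(C3=CC4CNCC(C3)C4)c2)c1`: 1 nM
- compound 2, `C1=C(c2cccnc2)C[C@H]2CNC[C@@H]1C2`: 0.2 nM

Of the compounds shown here, two have been measured in an in vitro assay on SH-EP1 cells for displacement of a labelled ligand from Neuronal acetylcholine receptor; alpha4/beta2 (Homo sapiens); on this read-out higher numbers stand for weaker inhibition and lower numbers for stronger inhibition. Compound 1 gives 1 nM, which is the higher of the two numbers. Compound 2, which carries no aryloxy group at all, gives 0.2 nM, and the gap between the two lies beyond the usual scatter of this kind of measurement. No single-point comparison between the two measured compounds is available, so their two values can only be read side by side.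

Compound 3, `Clc1ccccc1Oc1cncc(C2=CC3CNCC(C2)C3)c1`, has not yet been measured. It keeps every atom of compound 1 and differs only in how the chlorine sits on the phenoxy ring: 2-chlorophenyl in place of 3-chlorophenyl on an oxygen on an aromatic ring.

Because compound 1 already gives 1 nM and the change is a simple shift of one chlorine within the same ring, the step of a 2.0-fold higher number from compound 1 to compound 3 (0.30 log units; within the scatter) is expected to be small, most likely a slight weakening that may not exceed the scatter. Compound 3 is therefore estimated at 2 nM, with a range from 0.5 nM to 8 nM.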

Compound 3, inhibition constant: 0.9 nM
Estimate against measurement, compound 3: 2.2-fold (0.35 log units) above; the measured number falls inside the stated range.
By their numbers in this assay, from the lowest: compound 2; then compounds 3 and 1 (each within the scatter of the next).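

The swap of 2-chlorophenyl in place of 3-chlorophenyl on the oxygen gives, in this assay, a 1.1-fold lower number from compound 1 to compound 3 (0.05 log units; within the scatter), so these two placements of the chlorine cannot be told apart on this read-out. Among the compounds shown here, this is the first comparison here between two compounds that differ in one place, since compound 1 and compound 2 could only be read side by side; it shows that, with the same atoms joined differently, the number stays within the scatter for this pair. Nothing available here accounts for why the two placements read alike.

On these data alone, whether the chlorine itself matters remains open, since both compounds carry one on the phenoxy ring and a plain phenyl on the same oxygen would be the direct test. As far as these compounds go, it is also open whether this flat result extends to other groups on that ring, such as a methoxy group, a nitrile or an amine in place of the chlorine, and so whether the ring accepts change in general or only this one shift.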